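Swapping a Nitrophenyl for a Furan on the Shared Core

The compounds below may be only part of what the source reports. "The series", "measured", "known", "first", "only" and "open" are said of these compounds alone.

Compound 1 `O=C(c1ccncc1)N1N=C(c2cc3ccccc3o2)CC1c1ccccc1Cl` in an ADME assay on Vero cells (Chlorocebus sabaeus) for cytotoxicity, read by MTT assay, with a stated time of 72 h (a higher number here means a weaker inhibitor, a lower number a stronger inhibitor), gives only a limit, > 210000 nM.
Compound 2 `O=C(c1ccncc1)N1N=C(c2cc3ccccc3o2)CC1c1ccccc1[N+](=O)[O-]` in this assay gives only a limit, > 245000 nM.

Compound 2 thus stands at a limit of this assay rather than at a number, and so does compound 1. The step that the two limits leave unreadable from compound 1 to compound 2 has no readable size because the limit of > 210000 nM in this assay, at which 1 of the 2 values shown sits, and the limit of > 245000 nM in this assay, at which 1 of the 2 values shown sits, sit at both of its ends.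

Compound 3 `O=C(c1ccncc1)N1N=C(c2cc3ccccc3o2)CC1c1ccco1` differs from compound 2 in one place: furan-2-yl in place of 2-nitrophenyl on a saturated ring carbon. For the measured compounds named here, the only measured step at that position, from compound 1 to compound 2, bears on this change but gives no size. Compound 3 is therefore expected to show no step beyond the scatter, and most likely another limit. The expected step that the limit leaves unreadable from compound 2 to compound 3 is estimated as none beyond the scatter. The estimate for compound 3 in this assay is 250000 nM, with a range from 100000 nM to 600000 nM.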

Compound 3, half-maximal inhibitory concentration: > 208000 nM
Compound 3: no number, only a limit; the forecaster's own chance of this, stated with the estimate: 80%; the middle value lies beyond the limit too.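

Compound 3, like compound 1 and compound 2, gives only a limit in this assay, and no step among these three compounds can be read. On these data alone, what stays open is the actual value of each compound and how the three compare with one another.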